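Adding a Methyl Branch to the Amide Chain

The compounds below may be only part of what the source reports. "The series", "measured", "known", "first", "only" and "open" are said of these compounds alone.

Two measured compounds share one core and differ only in the chain on the amide carbonyl. Compound 1 `CC(=O)Nc1c(C(O)(C(F)(F)F)C(F)(F)F)ccc2ccccc12` carries the shortest chain, and in an assay on LtK cells with ATP-sensitive inward rectifier potassium channel 11 (Homo sapiens) as the target (a lower number here means that less compound is needed, a higher number that more compound is needed for the effect), compound 1 gives 18 nM. Compound 2 `CCCC(=O)Nc1c(C(O)(C(F)(F)F)C(F)(F)F)ccc2ccccc12` has a longer chain; in this assay compound 2 gives 131 nM, the higher of the two numbers, as the step of a 7.3-fold higher number from compound 1 to compound 2 (0.86 log units; beyond the scatter) shows. Compound 3 `CCC(C)C(=O)Nc1c(C(O)(C(F)(F)F)C(F)(F)F)ccc2ccccc12` is not yet measured; it differs from compound 2 by methyl in place of hydrogen on a saturated chain carbon bound to a carbonyl carbon and a saturated chain carbon. Within the data shown here, only the step from compound 1 to compound 2 bears on this, and it shows that enlarging the chain raised the number. A smaller rise is therefore expected for compound 3, a 1.7-fold higher number from compound 2 to compound 3 (0.23 log units; within the scatter). Compound 3 is expected to give 220 nM in this assay, between 90 nM and 600 nM.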

Compound 3, half-maximal effective concentration: 177000 nM
Compound 3: the middle estimate sits 800-fold (2.91 log units) below what was measured, outside the stated range (above it).
By their numbers in this assay, from the lowest: compound 1; then compound 2; then compound 3.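

A single methyl on the saturated chain carbon bound to the carbonyl carbon matters far more in this assay than the earlier chain lengthening: a 1400-fold higher number from compound 2 to compound 3 (3.13 log units; beyond the scatter) is a large step, whereas a 7.3-fold higher number from compound 1 to compound 2 (0.86 log units; beyond the scatter) is a modest one. Taken together, sec-butyl in place of methyl on the carbonyl carbon gives a 9800-fold higher number from compound 1 to compound 3 (3.99 log units; beyond the scatter), so branching at this position, and not only chain size, goes with the rise. Nothing measured here explains this jump. 

From the compounds shown here alone, whether isopropyl or a straight butyl chain on the carbonyl carbon would bring a rise of similar size remains open.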